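The compounds below may be only part of what the source reports. "The series", "measured", "known", "first", "only" and "open" are said of these compounds alone.

- Compound 1 `N/C(=N\O)c1cn(COC(CO)CO)c2ncnc(N)c12`: > 100000 nM
- Compound 2 `Nc1ncnc2c1ccn2C(CO)OC(CO)CO`: > 100000 nM
- Compound 3 `Nc1ncnc2c1ccn2COC(CO)CO`: not yet measured

In an ADME assay on HFF cells (Homo sapiens) for cytotoxicity (a higher number here means a weaker inhibitor, a lower number a stronger inhibitor), compound 2 stands at > 100000 nM, which is a limit of the assay and not a number. Compound 1 gives > 100000 nM, and this too is a limit. The record so far therefore shows only (the limit of > 100000 nM in this assay, at which 2 of the 2 values shown sit).

Compound 3 differs from compound 2 in one place: hydrogen in place of hydroxymethyl on a saturated chain carbon bound to an aromatic nitrogen and an oxygen on a saturated carbon. Hydrogen stands in place of hydroxymethyl on a saturated chain carbon bound to an aromatic nitrogen and an oxygen on a saturated carbon.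

Within the data shown here, no measured pair shows what such a change does in this assay, so no shift beyond the scatter is expected, and the assay may again report only a limit. The estimate is a number no higher from compound 2 to compound 3 (the limit leaves the size open), a step not expected to exceed the scatter. Compound 3 is expected at 100000 nM, with an estimated range from 50000 nM to 150000 nM.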

Compound 3, half-maximal inhibitory concentration: > 100000 nM
Compound 3: no number, only a limit; the forecaster's own chance of this, stated with the estimate: 85%; the middle value lies on the limit itself.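

In this assay compound 3 gives > 100000 nM, which is a limit of the assay and not a number. Its steps from compound 1 and from compound 2 therefore cannot be read. The compounds shown leave open whether either change shifts the half-maximal inhibitory concentration at all: the limit of > 100000 nM in this assay, at which 3 of the 3 values shown sit.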